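A few compounds are considered here, and "the series" means these few. Any claim that something is new, unique, unknown or untested is made for them only; others in the source may bear on it.

Of the compounds shown here, three built on a shared core have been tested in an ADME assay on HCT-116 cells (Homo sapiens) for cytotoxicity, read by CellTiter-Glo, with a stated time of 72 h (on this read-out higher numbers stand for weaker inhibition and lower numbers for stronger inhibition), and each of them sits at a limit of that test rather than at a number. Compound 1, with the structure `Cc1cc(C)c(S(=O)(=O)N2CCC(N3CCC(CCC#N)CC3)CC2)c(C)c1`, is one of them. In this assay compound 1 gives > 5000 nM, which is a limit. Compound 2, with the structure `COc1cccc(S(=O)(=O)N2CCC(N3CCC(C)CC3)CC2)c1`, gives > 5000 nM in this assay, again a limit. Compound 3, with the structure `CC1CCN(C2CCN(S(=O)(=O)c3sc(Cl)nc3C3CC3)CC2)CC1`, gives > 10000 nM in this assay, also a limit. So compound 1 stands where the other two stand: no value is known, only a floor beneath which the cytotoxicity does not reach, shared with two compounds at the limit of > 5000 nM in this assay, at which 2 of the 3 values shown sit, and one at the limit of > 10000 nM in this assay, at which 1 of the 3 values shown sits.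

The next compound, compound 4 with the structure `Cc1cc(C)c(S(=O)(=O)N2CCC(N3CCCCC3)CC2)c(C)c1`, differs from compound 1 in one place: hydrogen in place of 2-cyanoethyl on a saturated ring carbon. The core and the rest of the two compounds are the same.

No change between two measured compounds is available to set a scale for this step. With every measured value a limit, the expectation is that no shift beyond the scatter will be seen, so the step from compound 1 to compound 4 is estimated at a step that the limit leaves unreadable from compound 1 to compound 4. Compound 4 is therefore expected to give about 8000 nM in this assay, within a range of 3000 nM to 25000 nM, most likely again as a limit.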

Compound 4, half-maximal inhibitory concentration: > 5000 nM
Compound 4 gave a limit, no number (the forecaster's own chance of this, stated with the estimate: 85%); the middle value is on the limit's open side.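

Compound 1 and compound 4 both sit at a limit in this assay rather than at a number, so no step between them can be read: the limit of > 5000 nM in this assay, at which 3 of the 4 values shown sit.

The compounds shown leave open whether hydrogen in place of 2-cyanoethyl changes cytotoxicity at all, and at what concentration any of these compounds would inhibit the cells.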